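The source may hold more compounds than are shown below. What is called first, only, known or untested is meant among the compounds shown, and "the series" means these compounds.

In an in vitro functional assay on cells for agonist activity at Bombesin receptor subtype-3 (Mus musculus), read by luminescence and calcium flux (on this read-out lower numbers stand for an effect already at smaller amounts and higher numbers for an effect only at larger amounts of compound), compound 1 `CCCCc1cnc(C(C)Cc2ccc(-c3ccccc3C(=O)O)cc2)[nH]1` gives 184 nM, while compound 2 `Cc1cccc(Cc2cnc(CCc3ccc(-c4ccccc4C(=O)O)cc3)[nH]2)c1` gives 75 nM. Compound 2 thereby holds the lowest of the two numbers, and its gap to compound 1 lies beyond the usual scatter of repeated measurements. Compound 3 `O=C(O)c1ccccc1-c1ccc(CCc2ncc(Cc3ccccc3)[nH]2)cc1` differs from compound 2 by hydrogen in place of methyl on an aromatic carbon. Among the compounds with values here, no measured pair shows a change of this kind, so the step of a 1.5-fold higher number from compound 2 to compound 3 (0.17 log units; within the scatter) is expected to be small, toward a somewhat higher number if beyond the scatter at all. Compound 3 is therefore estimated to give 110 nM in this assay, within a range from 45 nM to 270 nM.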

Compound 3, half-maximal effective concentration: 11 nM
Compound 3: the middle estimate sits 10-fold (1.00 log units) above what was measured, and the stated range ends above it.
By their numbers in this assay, from the lowest: compound 3; then compound 2; then compound 1.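

In this assay the change from 3-methylbenzyl to benzyl brings a 6.8-fold lower number from compound 2 to compound 3 (0.83 log units; beyond the scatter) and so shows that this place on the six-membered aromatic ring responds to the loss of a single carbon. Here the compound with hydrogen, not the one with methyl, gives the lower number. No measurement shown offers a reason for this step.

On these data alone, it remains open whether methyl alone raises the number or whether other groups at this carbon, such as fluorine, methoxy or hydroxyl, do the same. As far as these compounds go, the effect of a methyl on the other ring carbons also stays open.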